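From a Ring-Bearing Side Chain Back to Bromine

This account rests on a few compounds, and the source may have more. Where it says the series, first, only, none or still open, it means among the compounds named here.

Values from a functional assay on ECa-109 cells for inhibition, with ECa-109 cell line (Homo sapiens) as the target, read by MTT assay, with a stated time of 48 h (a higher number here means a weaker inhibitor, a lower number a stronger inhibitor), are shown here:
Compound 1 `COc1ccc(-c2coc3cc(OCCCBr)ccc3c2=O)cc1` gives 39700 nM
Compound 2 `COc1ccc(-c2coc3cc(OCCCSC(=S)N4CCOCC4)ccc3c2=O)cc1` gives 34000 nM

The numbers of compound 2 and compound 1 lie within the usual scatter of each other, so neither ranks ahead. The next molecule is compound 3 `COc1ccc(-c2coc3cc(OCCBr)ccc3c2=O)cc1` and its change from compound 2 is one bromine atom in place of a group of 10 heavy atoms (6 carbon, 1 nitrogen, 1 oxygen, 2 sulfur; one six-membered non-aromatic ring with 2 hetero atoms), on a saturated chain carbon, two bonds along the chain from an oxygen on an aromatic ring as counted from the two structures. For the measured compounds named here, one measured step bears on this: a 1.2-fold lower number from compound 1 to compound 2 (0.07 log units; within the scatter) is also an exchange between a bromine and a ring-bearing group, and it stayed within the scatter. Compound 1 also carries bromine, but three bonds along the chain from an oxygen on an aromatic ring, whereas compound 3 has it two bonds along. Going by the values given here, no measured pair isolates that difference. No step beyond the scatter is therefore expected in this assay in either direction. The estimated move is a 1.1-fold higher number from compound 2 to compound 3 (0.02 log units; within the scatter) and it would stay within the scatter. For compound 3 the expected value is 36000 nM (estimated range from 16000 nM to 80000 nM).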

Compound 3, half-maximal inhibitory concentration: 55100 nM
For compound 3 the middle estimate is 1.5-fold (0.18 log units) below the measured one; measured number inside the range.
By their numbers in this assay, from the lowest: compounds 2, 1 and 3 (each within the scatter of the next).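

In this assay, for the compounds shown here, the step of a 1.4-fold higher number from compound 1 to compound 3 (0.14 log units; within the scatter) is the first measured comparison in which bromine stays and only its place on the chain changes, with bromo replacing bromomethyl. That step lies within the scatter, so this change gives no measurable difference. Exchanging the ring-bearing group for bromine, a 1.6-fold higher number from compound 2 to compound 3 (0.21 log units; within the scatter), also stays within the scatter, and nothing available explains these results.

Going by these compounds, the three compounds cover only bromine and this one ring-bearing group at the end of the chain, so the effect of an amine or a carboxylic acid there remains open. On these data alone, a longer chain also remains open, including whether it would give a step beyond the scatter.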